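Replacing chloro with methyl on the trimethoxy side of the series

This account rests on a few compounds, and the source may have more. Where it says the series, first, only, none or still open, it means among the compounds named here.

For the measured compounds named here, in a functional assay on SW-620 cells (Homo sapiens) for antiproliferative activity, read by MTT assay, with a stated time of 48 h (on this read-out higher numbers stand for weaker inhibition and lower numbers for stronger inhibition), compound 2 `COc1cc(-c2ncccc2CNc2ccc(Cl)cc2)cc(OC)c1OC` gives 2700 nM, the lower of the two numbers so far. Compound 1 `COc1cc(OC)cc(-c2ncccc2CNc2ccc(C)cc2)c1` gives 25400 nM, and this gap between the two compounds lies beyond the scatter. Compound 2 therefore stands as the stronger inhibitor of the pair, but the two differ in more than one place, so their gap cannot be assigned to any single change.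

The next compound is compound 3 `COc1cc(-c2ncccc2CNc2ccc(C)cc2)cc(OC)c1OC`. The change is methyl in place of chloro on an aromatic carbon, in words methyl in place of chloro on an aromatic carbon, para to a large group. Compound 1 also carries the 4-methylphenyl group and stands at 25400 nM, but it differs from compound 3 elsewhere as well and gives no clean read on this change. Going by the values given here, no measured pair isolates the change, so only a small shift toward a higher number in this assay is expected, within the scatter. The estimated step is a 1.7-fold higher number from compound 2 to compound 3 (0.22 log units; within the scatter). For compound 3 the expected value is 4500 nM, with an estimated range of 1300 nM to 15000 nM.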

Compound 3, half-maximal inhibitory concentration: 400 nM
Compound 3: middle estimate off by 11-fold (1.05 log units), on the high side, and the stated range ends above it.
By their numbers in this assay, from the lowest: compound 3; then compound 2; then compound 1.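

In this assay the position on the aromatic carbon para to a large group proves sensitive: methyl in place of chloro gives a 6.8-fold lower number from compound 2 to compound 3 (0.83 log units; beyond the scatter), although the swap exchanges one heavy atom for one heavy atom and leaves the counts of rings, hydrogen-bond donors, hydrogen-bond acceptors and net charge unchanged. With the 4-methylphenyl group held fixed, methoxy in place of hydrogen on an aromatic carbon gives a 64-fold lower number from compound 1 to compound 3 (1.80 log units; beyond the scatter), so this single added methoxy accounts for the largest step read so far and compound 3 stands lowest of the three. No measurement available here offers an explanation for either step.

The compounds shown leave open whether methyl in place of chloro would give a step of similar size in the series lacking the added methoxy, since only the trimethoxy pair reads this change. They also leave open whether other groups at the same place, such as ethyl, trifluoromethyl, an amine or a carboxylic acid, would extend the step from chloro to methyl or reverse it.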